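Methyl on the saturated ring of a chloro analog

The compounds below may be only part of what the source reports. "The series", "measured", "known", "first", "only" and "open" are said of these compounds alone.

The series comprises compound 1 `Cc1cccc(N2CC(C)NC(=O)N2)n1`, compound 2 `CC1CN(c2cccc(F)n2)NC(=O)N1` and compound 3 `O=C1NCCN(c2cccc(Cl)n2)N1`, all tested in a functional assay on cells for inhibition of Polyunsaturated fatty acid 5-lipoxygenase (Homo sapiens); on this read-out higher numbers stand for weaker inhibition and lower numbers for stronger inhibition. Compound 1 gives 1700 nM, compound 2 gives 6000 nM and compound 3 gives 4800 nM. Compound 3 thus stands second highest of the three numbers: its gap to compound 2 lies within the scatter, while compound 1 sits at a lower number beyond the scatter.

The unmeasured compound 4 `CC1CN(c2cccc(Cl)n2)NC(=O)N1` differs from compound 3 by methyl in place of hydrogen on a saturated ring carbon. Among the measured compounds shown here, no measured pair isolates this change. For the measured compounds named here, the one measured step, a 3.5-fold higher number from compound 1 to compound 2 (0.55 log units; beyond the scatter), concerns a fluoro in place of methyl on an aromatic carbon and does not bear on a methyl on a saturated ring carbon. Compound 2 and compound 3 differ in both the group on the aromatic carbon and the methyl on the saturated ring carbon, so their two values show only that the combination of fluoro with methyl lands within the scatter of chloro without methyl.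

Going by the values given here, with no direct precedent, compound 4 is expected to stay close to compound 3, a step of a 1.2-fold lower number from compound 3 to compound 4 (0.08 log units; within the scatter), within the scatter. Compound 4 is therefore estimated at 4000 nM, between 1500 nM and 10000 nM.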

Compound 4, half-maximal inhibitory concentration: 1600 nM
Estimate against measurement, compound 4: 2.5-fold (0.40 log units) above; low and high end bracket the measured number.
By their numbers in this assay, from the lowest: compounds 4 and 1 (each within the scatter of the next); then compounds 3 and 2 (each within the scatter of the next).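

In this assay, among the compounds shown here, methyl in place of hydrogen on a saturated ring carbon, next to the ring nitrogen, gives a 3.0-fold lower number from compound 3 to compound 4 (0.48 log units; beyond the scatter) and so provides the first pair that isolates this change, showing that with chloro on the aromatic carbon this single added methyl moves the number beyond the scatter. With the ring methyl present, chloro in place of fluoro on an aromatic carbon gives a 3.8-fold lower number from compound 2 to compound 4 (0.57 log units; beyond the scatter), which is beyond the scatter, while replacing the aromatic methyl by chloro gives a 1.1-fold lower number from compound 1 to compound 4 (0.03 log units; within the scatter), which is within it, so among these three compounds only fluoro stands apart, at the higher number. Nothing measured here speaks to the reason for the change at the saturated ring carbon.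

The effect of the ring methyl is seen only with chloro on the aromatic carbon, since neither compound 1 nor compound 2 has a partner without it among the compounds shown. Going by these compounds, whether an ethyl, a hydroxymethyl or an amine on the same saturated ring carbon would keep the lower number also stays open.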